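The source may hold more compounds than are shown below. What is called first, only, known or untested is meant among the compounds shown, and "the series" means these compounds.

Measured in a functional assay on MGC-803 cells (Homo sapiens) for antiproliferative activity, read by CellTiter-Glo, with a stated time of 72 h; on this read-out higher numbers stand for weaker inhibition and lower numbers for stronger inhibition:
Compound 1 `O=C(NO)c1ccc(/C=C/c2ccnc(-c3cccc(CO)c3)c2)cc1`: 1740 nM
Compound 2 `O=C(NO)c1ccc(/C=C/c2ccnc(-c3cccnc3)c2)cc1`: 4550 nM
Compound 3 `O=C(NO)c1ccc(/C=C/c2ccncc2)cc1`: 3930 nM

Compound 3 carries only hydrogen at the carbon where compound 1 and compound 2 carry a ring group. Among the three, compound 1 gives the lowest number, and compound 3 cannot be told apart from compound 2.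

The step in question leads to compound 4 `O=C(NO)c1ccc(/C=C/c2ccnc(-c3ccsc3)c2)cc1`, with thiophen-3-yl in place of hydrogen on an aromatic carbon, next to the ring nitrogen: thiophen-3-yl in place of hydrogen on an aromatic carbon. Going by the values given here, two measured steps bear on it, both read in reverse, as each replaces a ring group at that carbon with hydrogen. Losing pyridin-3-yl gave a 1.2-fold lower number from compound 2 to compound 3 (0.06 log units; within the scatter). Losing 3-(hydroxymethyl)phenyl gave a 2.3-fold higher number from compound 1 to compound 3 (0.35 log units; beyond the scatter), a modest change. Neither group is thiophen-3-yl, so these steps only frame the expectation. In this assay, a small move towards a lower number is expected, probably not clearing the scatter, and a large step is not expected.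

The estimate for compound 4 is 2800 nM, with an expected range from 1300 nM to 5500 nM. This estimate amounts to a 1.4-fold lower number from compound 3 to compound 4 (0.15 log units; within the scatter).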

Compound 4, half-maximal inhibitory concentration: 3680 nM
Compound 4: middle estimate off by 1.3-fold (0.12 log units), on the low side; measured number inside the range.
By their numbers in this assay, from the lowest: compound 1; then compounds 4, 3 and 2 (each within the scatter of the next).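

In this assay, thiophen-3-yl on this aromatic carbon, next to the ring nitrogen, gives a 1.1-fold lower number from compound 3 to compound 4 (0.03 log units; within the scatter), and exchanging pyridin-3-yl for it gives a 1.2-fold lower number from compound 2 to compound 4 (0.09 log units; within the scatter), so a five-membered aromatic ring with sulfur now joins the six-membered pyridin-3-yl in leaving the number indistinguishable from that of the compound with only hydrogen here. Compound 1 goes against any idea that a ring group at this carbon is enough to move the number, and replacing its 3-(hydroxymethyl)phenyl with thiophen-3-yl gives a 2.1-fold higher number from compound 1 to compound 4 (0.33 log units; beyond the scatter), which makes 3-(hydroxymethyl)phenyl the only group shown that stands apart from hydrogen, although the change is modest. Nothing available here explains why the three groups differ in this way.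

The compounds shown leave open whether the difference seen with compound 1 belongs to the hydroxymethyl group or to the phenyl ring carrying it, a question that plain phenyl would help to settle. They also leave open whether an aminomethyl group or a carboxylic acid in place of hydroxymethyl would keep, lose or extend that difference.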